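A few compounds are considered here, and "the series" means these few. Any claim that something is new, unique, unknown or untested is made for them only; others in the source may bear on it.

Three compounds of the series have results in a functional assay on MCF7 cells (Homo sapiens) for antiproliferative activity, read by MTT assay, with a stated time of 72 h; a lower number here means a stronger inhibitor, a higher number a weaker inhibitor. Compound 1 `O=c1c(Cl)c(CSC(=S)N2CCOCC2)oc2ccccc12` gives 11100 nM in this assay. Compound 2 `O=c1c(CSC(=S)N2CCCCC2)coc2cc(Cl)ccc12` gives 380 nM in this assay, so of the two numbers compound 1 stands highest, and compound 2, the nearest, lies well beyond the scatter below it. Compound 3 `CCOC(=O)c1cc(=O)c2cc(CSC(=S)N(C(C)C)C(C)C)ccc2o1` reaches only > 25000 nM in this assay, which is a limit of the assay and not a number (the limit of > 25000 nM in this assay, at which 1 of the 3 values shown sits).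

Compound 4 `CC(C)N(C(=S)SCc1oc2ccccc2c(=O)c1Cl)C(C)C` has not yet been measured. It differs from compound 1 in one place: diisopropylamino in place of morpholin-4-yl on a thiocarbonyl carbon. Among the measured compounds shown here, no measured pair in the set shows this exchange on the shared core, so nothing directly fixes its size. For the measured compounds named here, the only other compound with diisopropylamino, compound 3, sits on a different core and carries the limit noted above. Compound 4 is therefore expected to sit at 15000 nM in this assay, within 5000 nM to 40000 nM. The step expected from this is a 1.4-fold higher number from compound 1 to compound 4 (0.13 log units; within the scatter), that is, no change beyond the scatter, with a weaker result more likely than a stronger one.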

Compound 4, half-maximal inhibitory concentration: > 40000 nM
Compound 4 ended at the assay's limit (the forecaster's own chance of this, stated with the estimate: 25%); middle value at least 2.6-fold (0.42 log units) away from the limit.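

In this assay, among the compounds shown here, diisopropylamino in place of morpholin-4-yl on a thiocarbonyl carbon of the shared core gives an at least 3.6-fold higher number from compound 1 to compound 4 (0.55 log units; beyond the scatter), the first direct reading of this exchange. The result for compound 4 is a limit of the assay and not a number: the limit of > 40000 nM in this assay, at which 1 of the 4 values shown sits.

Compound 3, the only other compound with diisopropylamino, stands on a different core and also gives a limit: the limit of > 25000 nM in this assay, at which 1 of the 4 values shown sits.

The compounds shown do not tell whether the step comes from gaining diisopropylamino or from losing morpholin-4-yl, and they give no actual number for any compound with diisopropylamino. As far as these compounds go, it also stays open how dimethylamino or a piperazine ring on the same thiocarbonyl carbon of the core of compound 1 would read in this assay.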